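Swapping bromo for methyl on the outer phenyl ring

The source may report more compounds than this note shows. Statements on the series, on what has been measured and on what is new or still open speak of the compounds shown alone.

Of the compounds shown here, three sharing one core have been tested in a functional assay on the whole organism for inhibition, with Mus musculus as the target, with a stated time of 5 h, at a dose of 50 mg/kg by the oral route; a higher number here means more inhibition at the dose given (going by the name of the read-out), a lower number less inhibition. Compound 1 `Cc1ccc(-c2c(S(=O)(=O)c3ccccc3)cnc3cc(C)nn23)cc1` gives 8.1%. Compound 2 `Cc1ccc(-c2c(S(=O)(=O)c3ccccc3)cnc3cc(-c4ccccc4)nn23)cc1` gives 28.2%, and compound 3 `Cc1ccc(-c2c(S(=O)(=O)c3ccccc3)cnc3cc(-c4ccc(Br)cc4)nn23)cc1` gives 31.7%. Compound 3 shows the highest of the three numbers, but its value and that of compound 2 lie within the scatter of each other, so the two cannot be ranked; only compound 1 stands clearly apart, as the step of a number 23.6 percentage points higher from compound 1 to compound 3 (beyond the scatter) shows.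

Compound 4 `Cc1ccc(-c2cc3ncc(S(=O)(=O)c4ccccc4)c(-c4ccc(C)cc4)n3n2)cc1` has not yet been measured. It differs from compound 3 by methyl in place of bromo on an aromatic carbon. Among the measured compounds shown here, the one step that touches the same position is a number 3.5 percentage points higher from compound 2 to compound 3 (within the scatter), a change that stayed within the scatter. The two larger steps, a number 20.1 percentage points higher from compound 1 to compound 2 (beyond the scatter) and a number 23.6 percentage points higher from compound 1 to compound 3 (beyond the scatter), came from putting a whole phenyl or 4-bromophenyl in place of methyl on the core, and they were of similar size whether or not the bromo was present. For the measured compounds named here, nothing among the measured compounds suggests that exchanging bromo for methyl on the outer ring should move the read-out beyond the scatter, so the expected step of a number 1.7 percentage points lower from compound 3 to compound 4 (within the scatter) is small and of uncertain direction. Compound 4 is therefore expected to give about 30%, with a range from 15% to 45% in this assay.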

Compound 4, a percentage reported as inhibition, in the whole organism at one dose (the size of the read-out at that dose, not a potency): 17%
The estimate for compound 4 lay 13 percentage points above the measured number; the range from low to high includes it.
By their numbers in this assay, from the lowest: compounds 1 and 4 (each within the scatter of the next); then compounds 2 and 3 (each within the scatter of the next).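

The outer ring position is less indifferent than the bromo step alone suggested: in this assay methyl in place of bromo gives a number 14.7 percentage points lower from compound 3 to compound 4 (beyond the scatter) and methyl in place of hydrogen gives a number 11.2 percentage points lower from compound 2 to compound 4 (beyond the scatter), while bromo in place of hydrogen gave only a number 3.5 percentage points higher from compound 2 to compound 3 (within the scatter), so hydrogen and bromo cannot be told apart here, yet methyl stands apart from both. The gain seen on replacing the methyl on the core with phenyl or 4-bromophenyl does not carry over to 4-methylphenyl, since that exchange gives a number 8.9 percentage points higher from compound 1 to compound 4 (within the scatter), which makes compound 4 the exception among these compounds. Nothing measured here accounts for methyl parting from the other two.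

From the compounds shown here alone, whether this drop belongs to methyl alone remains open, as a chloro, a methoxy, an amine or a carboxylic acid on the same carbon could side with either methyl or bromo. Going by these compounds, with only one dose and one time point at hand, it is also open whether the gap between methyl and bromo would hold under other conditions.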